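A few compounds are considered here, and "the series" means these few. Any claim that something is new, unique, unknown or untested is made for them only; others in the source may bear on it.

Compound 1 `CC1=C(/C=C/C(=O)/C=C/c2ccccc2)C(C)(C)CCC1O` carries an unsubstituted phenyl ring. In a functional assay on PC-3 cells (Homo sapiens) for cytotoxicity, read by MTT assay, with a stated time of 72 h (a lower number here means a stronger inhibitor, a higher number a weaker inhibitor), compound 1 gives 15500 nM. Compound 2 `CC1=C(/C=C/C(=O)/C=C/c2ccccc2C(F)(F)F)C(C)(C)CCC1O` differs by trifluoromethyl in place of hydrogen on an aromatic carbon, and in this assay compound 2 gives 3700 nM, so that a 4.2-fold lower number from compound 1 to compound 2 (0.62 log units; beyond the scatter). Compound 3 `CC1=C(/C=C/C(=O)/C=C/c2cccc(F)c2)C(C)(C)CCC1O` differs from compound 1 by fluoro in place of hydrogen on an aromatic carbon, and in this assay compound 3 gives 16000 nM, so that a 1.0-fold higher number from compound 1 to compound 3 (0.01 log units; within the scatter).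

Compound 4 `CC1=C(/C=C/C(=O)/C=C/c2cc(F)cc(C(F)(F)F)c2)C(C)(C)CCC1O` is compound 3 with trifluoromethyl in place of hydrogen on an aromatic carbon. This is the same kind of change as from compound 1 to compound 2, but not the same: in compound 2 the trifluoromethyl sits ortho to a large group, whereas in compound 4 it sits meta to a fluoro group and meta to a large group. Among the measured compounds shown here, the one measured example of this change is the step from compound 1 to compound 2, so the expectation for compound 4 rests on that step alone, with the different surroundings adding uncertainty. The estimated step is a 2.9-fold lower number from compound 3 to compound 4 (0.46 log units; beyond the scatter), and compound 4 is expected to give about 5500 nM, within 2500 nM to 12000 nM.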

Compound 4, half-maximal inhibitory concentration: 3000 nM
Estimate against measurement, compound 4: 1.8-fold (0.26 log units) above, and the stated range covers the measured number.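

In this assay, the new step with trifluoromethyl in place of hydrogen on an aromatic carbon is a 5.3-fold lower number from compound 3 to compound 4 (0.73 log units; beyond the scatter). Set beside the earlier example, the change carries over from a ring without fluoro to one with a fluoro group, and its size stays much the same: the same change on two cores in this assay, a 4.2-fold lower number (0.62 log units; beyond the scatter) from compound 1 to compound 2 and a 5.3-fold lower number (0.73 log units; beyond the scatter) from compound 3 to compound 4, 1.3-fold (0.10 log units) apart, within the scatter of two such steps. Among the compounds shown here, this agreement rests on only two pairs in a single cell assay, with the trifluoromethyl at a different place in each pair, so it does not show that the step would hold on other cores, and it does not explain why the number falls.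

The compounds shown leave open whether other groups on the aromatic ring, such as a nitrile, a methoxy group or an amine, would lower the number as far as trifluoromethyl does. They also leave open what would happen if the hydroxyl group on the shared core gave way to a carboxylic acid.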